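The source may hold more compounds than are shown below. What is called first, only, known or untested is meant among the compounds shown, and "the series" means these compounds.

Compound 1, `CCCCCC(=O)NCC(C)(C)CC1=C(O)C(=O)c2ccccc2C1=O`: 40200 nM
Compound 2, `CCCCCC(=O)OCC(C)(C)CC1=C(O)C(=O)c2ccccc2C1=O`: 41000 nM

Among the measured compounds shown here, in a functional assay on KB cells (Homo sapiens) for cytotoxicity, read by resazurin assay, with a stated time of 3 days (a lower number here means a stronger inhibitor, a higher number a weaker inhibitor), compound 2 gives 41000 nM, and the only measured step, a 1.0-fold higher number from compound 1 to compound 2 (0.01 log units; within the scatter), lies within the scatter, so compound 2 and compound 1 stand level. Compound 3, `CCCCCCCCCCCCCC(=O)OCC(C)(C)CC1=C(O)C(=O)c2ccccc2C1=O`, differs from compound 2 by octyl in place of hydrogen on a saturated chain carbon, five bonds along the chain from a carbonyl carbon. For the measured compounds named here, no measured step touches this part of the molecule; the single step seen concerns the linker and is within the scatter, so nothing in hand points to a shift in either direction. Compound 3 is therefore expected near 38000 nM, in the range 12000 nM to 120000 nM. The expected step of a 1.1-fold lower number from compound 2 to compound 3 (0.03 log units; within the scatter) is within the scatter.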

Compound 3, half-maximal inhibitory concentration: 51400 nM
Compound 3: the middle estimate sits 1.4-fold (0.13 log units) below what was measured, within the range that was stated.
By their numbers in this assay, from the lowest: compounds 1, 2 and 3 (each within the scatter of the next).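

Octyl in place of hydrogen on a saturated chain carbon, five bonds along the chain from a carbonyl carbon, gives a 1.3-fold higher number from compound 2 to compound 3 (0.10 log units; within the scatter) in this assay. The earlier compounds shown here did not touch this position, and this first change here leaves the two numbers level, even though the added group is a sizeable chain. Nothing measured bears on why this is so. On these data alone, whether an amine or a carboxylic acid at the end of this chain would give a different number remains open. So does whether the octyl change would also leave the number level on the amide of compound 1.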